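The source may hold more compounds than are shown below. What is called first, only, known or untested is meant among the compounds shown, and "the series" means these compounds.

Measured in a functional assay (trachea) with Rattus norvegicus as the target; on this read-out lower numbers stand for lower potency and higher numbers for higher potency (the scale is a negative logarithm):
compound 1 `CC1(C)C=C(n2ccccc2=O)c2cc(C(=O)c3ccc(O)cc3)ccc2O1` gives 5.87
compound 2 `CC1(C)C=C(n2ccccc2=O)c2cc(C(=N)NO)ccc2O1` gives 5.51
compound 3 `CC1(C)C=C(n2ccccc2=O)c2cc(OS(=O)(=O)F)ccc2O1` gives 7.22

Compound 3 stands highest of the three measured numbers: the steps of a number 1.35 log units higher from compound 1 to compound 3 (beyond the scatter) and a number 1.71 log units higher from compound 2 to compound 3 (beyond the scatter) are both large and beyond the scatter, so compound 3 is the most potent of the measured set. Compound 4 `CC1(C)C=C(n2ccccc2=O)c2cc(-c3ccncc3)ccc2O1` has not yet been measured. Its difference from compound 3 is pyridin-4-yl in place of (fluorosulfonyl)oxy on an aromatic carbon. For the measured compounds named here, the steps that bear on it are a number 1.35 log units higher from compound 1 to compound 3 (beyond the scatter) and a number 1.71 log units higher from compound 2 to compound 3 (beyond the scatter): each shows (fluorosulfonyl)oxy standing well above another substituent at the same aromatic carbon, one of them (4-hydroxyphenyl)carbonyl, which like pyridin-4-yl brings a six-membered aromatic ring. Going by the values given here, no measured step tells how pyridin-4-yl itself fares, so the expectation rests on this read-across only. A downward step beyond the scatter is therefore expected, roughly reversing the gain seen from compound 1 to compound 3, with wide uncertainty. Compound 4 is estimated at 6.2, within 5.4 to 7. The expected step is a number 1.02 log units lower from compound 3 to compound 4 (beyond the scatter).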

Compound 4, logarithm of the reciprocal of the active concentration, log(1/C): 6.32
Compound 4: middle estimate off by 0.12 log units, on the low side, and the stated range covers the measured number.
By their numbers in this assay, from the lowest: compound 2; then compound 1; then compound 4; then compound 3.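

In this assay, pyridin-4-yl gives this aromatic carbon an intermediate substituent, with the steps of a number 0.90 log units lower from compound 3 to compound 4 (beyond the scatter), a number 0.81 log units higher from compound 2 to compound 4 (beyond the scatter) and a number 0.45 log units higher from compound 1 to compound 4 (beyond the scatter). A six-membered aromatic ring at this position therefore need not stay at the level of compound 1, though with the ring attached directly and carrying a ring nitrogen, this change does not reach compound 3, whose (fluorosulfonyl)oxy group remains the most potent of the four. Nothing measured here explains these differences.

The compounds shown leave open how a plain phenyl ring would compare with pyridin-4-yl at this aromatic carbon, which would separate the ring from its nitrogen. Also open, going by these compounds, is whether a nitrile, a carboxylic acid or an amine at the same carbon could match compound 3.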